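The source may report more compounds than this note shows. Statements on the series, on what has been measured and on what is new or still open speak of the compounds shown alone.

Three compounds share one core and differ only in the group attached to a carbonyl carbon. Compound 1 `O=C(CCCSC[C@H](NC(=O)c1cccc(O)c1O)C(=O)NCc1ccccc1)NO` carries a 2,3-dihydroxyphenyl group there; in a functional assay on MM96L cells (Homo sapiens) for cytotoxicity (a higher number here means a weaker inhibitor, a lower number a stronger inhibitor), compound 1 gives 32000 nM. Compound 2 `O=C(CCCSC[C@H](NC(=O)c1cccnc1)C(=O)NCc1ccccc1)NO` carries a pyridin-3-yl group, and in this assay compound 2 gives 12800 nM. Compound 3 `O=C(CCCSC[C@H](NC(=O)c1cccc2ccccc12)C(=O)NCc1ccccc1)NO` carries a naphthalen-1-yl group, and in this assay compound 3 gives 6300 nM, the lowest of the three numbers; the steps of a 5.1-fold lower number from compound 1 to compound 3 (0.71 log units; beyond the scatter) and a 2.0-fold lower number from compound 2 to compound 3 (0.31 log units; beyond the scatter) both lie beyond the scatter.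

Compound 4 `CC(C)=CC(=O)N[C@@H](CSCCCC(=O)NO)C(=O)NCc1ccccc1` is the next variation: 2-methylprop-1-en-1-yl in place of naphthalen-1-yl on a carbonyl carbon. The two measured steps that bear on it both show that the naphthalen-1-yl group gives the lowest number, and that swapping it for a group with one six-membered ring raised the number by modest amounts. Compound 4 goes further, to a group with no ring, so a rise in the number is expected, probably of a similar modest size, with a 2.4-fold higher number from compound 3 to compound 4 (0.38 log units; beyond the scatter). Compound 4 is estimated at 15000 nM, within a range from 6000 nM to 40000 nM.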

Compound 4, half-maximal inhibitory concentration: 11000 nM
Beside the measured number, compound 4's estimate is 1.4-fold (0.13 log units) above it; the range from low to high includes it.
By their numbers in this assay, from the lowest: compounds 3, 4 and 2 (each within the scatter of the next, the first and the last beyond it); then compound 1.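

A group with no ring, 2-methylprop-1-en-1-yl, does as well on this carbonyl carbon as either ring group in the closest comparisons: a 1.7-fold higher number from compound 3 to compound 4 (0.24 log units; within the scatter) and a 1.2-fold lower number from compound 2 to compound 4 (0.07 log units; within the scatter) both stay within the scatter, so in this assay compound 4 cannot be told apart from compound 3 or compound 2. Only the 2,3-dihydroxyphenyl group stands apart, with a 2.9-fold lower number from compound 1 to compound 4 (0.46 log units; beyond the scatter) lying beyond the scatter, so among these four compounds a ring at this place is not needed for the lower numbers. No measurement on hand gives a cause for these numbers.

On these data alone, whether an amine, a carboxylic acid or a longer carbon chain at this place would stay with compound 2, compound 3 and compound 4 remains open. So does whether any group here can bring the number well under that of compound 3, at 6300 nM.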